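The source may report more compounds than this note shows. Statements on the series, on what has been measured and on what is new or still open speak of the compounds shown alone.

Working notes on the series. Compound 1 `O=C1NCCN(c2cccc(Cl)n2)N1` gives 4800 nM in a functional assay on cells for inhibition of Polyunsaturated fatty acid 5-lipoxygenase (Homo sapiens) (a higher number here means a weaker inhibitor, a lower number a stronger inhibitor), and compound 2 `O=C1NCCN(c2cccc(Br)n2)N1` gives 4600 nM in this assay. Among the measured compounds shown here, the one recorded step, a 1.0-fold lower number from compound 1 to compound 2 (0.02 log units; within the scatter), shows that exchanging the halogen on the aromatic carbon moves nothing here. For the measured compounds named here, on the two numbers so far compound 2 stands at the lower figure, with compound 1 a near-equal neighbour, the gap being within the scatter.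

Compound 3 `O=C1NCCN(c2cccc(-c3cccs3)n2)N1` is not yet measured. Relative to compound 2 the change is thiophen-2-yl in place of bromo on an aromatic carbon. Going by the values given here, no step on record replaces a halogen with a ring at this position; the only measured step, a halogen-for-halogen swap, stayed within the scatter and bears on it only loosely. The expectation in this assay is therefore a step of uncertain direction, most likely not beyond the scatter, with wide bounds. Compound 3 is estimated at 3500 nM, range 900 nM to 14000 nM, corresponding to an expected step of a 1.3-fold lower number from compound 2 to compound 3 (0.12 log units; within the scatter).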

Compound 3, half-maximal inhibitory concentration: 37000 nM
Compound 3: the middle estimate sits 11-fold (1.02 log units) below what was measured; measured number above the stated range.
By their numbers in this assay, from the lowest: compounds 2 and 1 (each within the scatter of the next); then compound 3.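

In this assay the position on the aromatic carbon next to the ring nitrogen, which showed no response to the exchange of one halogen for the other, does respond to a ring: an 8.0-fold higher number from compound 2 to compound 3 (0.91 log units; beyond the scatter), and a 7.7-fold higher number from compound 1 to compound 3 (0.89 log units; beyond the scatter). The tolerance seen between chloro and bromo therefore does not extend to thiophen-2-yl, with its five heavy atoms and five-membered aromatic ring, and the change here runs towards weaker inhibition. Nothing on hand bears on what lies behind this rise.

Only chloro, bromo and thiophen-2-yl are shown at this position, so one ring replacement has to stand for all groups other than halogens. As far as these compounds go, whether a phenyl ring, a methyl group or an amine would give a number near that of compound 2 or near that of compound 3 remains open.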